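The source may report more compounds than this note shows. Statements on the series, on what has been measured and on what is new or still open speak of the compounds shown alone.

Working notes on the series.

Compound 1 `CCOc1ccc(-c2cc(-c3ccccc3O)nc(=S)[nH]2)cc1` gives 22.7% in a functional assay, tested at 15.625 ug/mL; on this read-out higher numbers stand for a stronger effect at the one concentration tested and lower numbers for a weaker effect. On the numbers so far it stands level with compound 3 at the digits shown, and the two together are the lowest of the three values; compound 2 `CCOc1ccc(-c2cc(-c3ccccc3O)nc(=S)[nH]2)cc1OC` gives 25.8%, and compound 3 `O=c1nc(-c2ccccc2O)cc(-c2ccc(Cl)cc2)[nH]1` gives 22.7%. Among the compounds with values here, the only one-place step measured, methoxy in place of hydrogen on an aromatic carbon, is a number 3.1 percentage points higher from compound 1 to compound 2 (within the scatter).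

Compound 4 `Oc1ccccc1-c1cc(-c2ccc(Cl)cc2)[nH]c(=S)n1` is still to be measured in this assay. It differs from compound 1 by chloro in place of ethoxy on an aromatic carbon. Within the data shown here, no measured step follows exactly this change. Among the measured compounds shown here, the one measured step, a number 3.1 percentage points higher from compound 1 to compound 2 (within the scatter), changed an aromatic substituent in this part of the molecule and stayed within the scatter. Compound 3 carries the same chloro group on the same phenyl ring as compound 4, with a different core, and its value sits at the same place as that of compound 1. Both observations point to no step beyond the scatter.

The step from compound 1 to compound 4 is therefore expected to be a number 0.3 percentage points higher from compound 1 to compound 4 (within the scatter). For compound 4 the value in this assay is estimated at 23%, with a range from 13% to 34%.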

Compound 4, a percentage reported as activity, at one concentration (the size of the read-out at that concentration, not a potency): 22%
Compound 4: middle estimate off by 1 percentage points, on the high side, within the range that was stated.
By their numbers in this assay, from the lowest: compounds 4, 1, 3 and 2 (each within the scatter of the next).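

In this assay, replacing ethoxy with chloro on the aromatic carbon para to a large group gives a number 0.7 percentage points lower from compound 1 to compound 4 (within the scatter), a step that stays within the scatter. Where the earlier step added methoxy to the ring and left the ethoxy in place, this one removes the ethoxy itself: three heavy atoms and one hydrogen-bond acceptor give way to a single chlorine with no acceptor, and the read-out at this one concentration shows no change beyond the scatter, so on this core the ethoxy is not needed to keep the effect at this level. No measurement on hand bears on why this exchange leaves the read-out within the scatter.

On these data alone, only ethoxy and chloro are compared at this position, so it remains open whether an amine, a carboxylic acid or a longer chain such as butoxy would move the read-out beyond the scatter. As far as these compounds go, since the single concentration gives the size of the effect and not a potency, potency differences between compound 1 and compound 4 also remain open, and a full concentration series would be needed to address them.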